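This account rests on a few compounds, and the source may have more. Where it says the series, first, only, none or still open, it means among the compounds named here.

Measured in a physicochemical assay for solubility, read by HPLC, using the shake flask method, with a stated time of 2 h, at pH 2; a higher number here means a more soluble compound, a lower number a less soluble compound:
- compound 1 `Nc1ncc(-c2ccc(C(=O)N3CCC(N)CC3)cc2)nc1-c1ccc(C(F)(F)F)cc1`: 200000 nM
- compound 2 `Nc1ncc(-c2ccc(C(=O)N3CC[C@@H](O)C3)cc2)nc1-c1ccc(C(F)(F)F)cc1`: 103000 nM

Within the data shown here, compound 2 stands within the scatter of compound 1, the only other compound measured. Compound 3 `Nc1ncc(-c2ccc(C(=O)N3CCC(O)CC3)cc2)nc1-c1ccc(C(F)(F)F)cc1` is still to be measured, and it differs from compound 2 as follows: 4-hydroxypiperidin-1-yl in place of 3-hydroxypyrrolidin-1-yl on a carbonyl carbon. Among the measured compounds shown here, one measured step bears on this change, since it also exchanged the group on a carbonyl carbon: a 1.9-fold lower number from compound 1 to compound 2 (0.29 log units; within the scatter). On that evidence, no step beyond the scatter is expected in this assay, and the direction is left open. The expected step is a 1.2-fold higher number from compound 2 to compound 3 (0.07 log units; within the scatter). Compound 3 is estimated at 120000 nM, with an expected range of 55000 nM to 220000 nM.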

Compound 3, solubility: 119000 nM
Compound 3: middle estimate off by 1.0-fold (0.00 log units), on the high side, and the stated range covers the measured number.
By their numbers in this assay, from the lowest: compounds 2, 3 and 1 (each within the scatter of the next).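

In this assay, the earlier step changed the ring and its substituent together, whereas compound 3 separates the two exchanges. Exchanging 3-hydroxypyrrolidin-1-yl for 4-hydroxypiperidin-1-yl on the carbonyl carbon gives a 1.2-fold higher number from compound 2 to compound 3 (0.06 log units; within the scatter), and hydroxy in place of amino on a saturated ring carbon gives a 1.7-fold lower number from compound 1 to compound 3 (0.23 log units; within the scatter), so neither exchange alone moves the number beyond the scatter. No supporting evidence is available to explain these numbers. On these data alone, whether a carboxylic acid on the saturated ring, or an open chain ending in an amine on the carbonyl carbon, would move the number beyond the scatter remains open.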